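Swapping a nitrile chain end for an amide

The source may report more compounds than this note shows. Statements on the series, on what has been measured and on what is new or still open speak of the compounds shown alone.

Measured compounds:
compound 1, `CCCCc1cc(C(C)=O)c(O)cc1OCCCCC#N`: 41%
compound 2, `CCc1cc(C(C)=O)c(O)cc1OCCCCCCCC(C)(C)C#N`: 66%
compound 3, `C=CCc1cc(C(C)=O)c(O)cc1OCCCCCC(=O)N(C)C`: 92%

All three were tested in an assay on isolated protein for inhibition of leukotriene B4 receptor 1 (Homo sapiens), tested at 10 uM; a higher number here means more inhibition at the concentration tested (going by the name of the read-out), a lower number less inhibition. Compound 2 stands second highest of the three numbers. Compound 1 sits lower, a gap beyond the usual scatter, while compound 3 sits higher, again beyond the scatter. Among the measured compounds shown here, no single-point steps between measured compounds are available, so these gaps are simply what the values show.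

The unmeasured compound 4, `CCc1cc(C(C)=O)c(O)cc1OCCCCCCC(=O)N(C)C`, differs from compound 2 in one place: dimethylcarbamoyl in place of 2-cyano-2-methylpropyl on a saturated chain carbon, six bonds along the chain from an oxygen on an aromatic ring. Compound 3 also carries a dimethylcarbamoyl group at the end of its chain and gives the highest value of the set, although it differs from compound 4 elsewhere as well. On this basis the step from compound 2 to compound 4 is expected to be an increase beyond the scatter, a number 14 percentage points higher from compound 2 to compound 4 (beyond the scatter). Compound 4 is therefore estimated at 80%, within a range from 60% to 95%.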

Compound 4, a percentage reported as inhibition, at one concentration (the size of the read-out at that concentration, not a potency): 100%
Estimate against measurement, compound 4: 20 percentage points below; measured number above the stated range.
By their numbers in this assay, from the lowest: compound 1; then compound 2; then compounds 3 and 4 (each within the scatter of the next).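

In this assay, putting dimethylcarbamoyl in place of 2-cyano-2-methylpropyl on a saturated chain carbon, six bonds along the chain from an oxygen on an aromatic ring, gives a number 34 percentage points higher from compound 2 to compound 4 (beyond the scatter). Among the compounds shown here, the earlier compounds differed in several places at once, so this is the first direct sign that the chain end alone can shift the read-out strongly, with the rest of the molecule unchanged. Nothing available explains why the result moves this way.

Compound 4, at 100%, sits at the top of a percentage scale at a single concentration, so any further gain from this change would not show here. A carboxylic acid or a primary amide at the chain end, or a plain nitrile without the two methyl groups on this same chain, would help show which part of the swap matters.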